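This account rests on a few compounds, and the source may have more. Where it says the series, first, only, none or still open, it means among the compounds named here.

Measured in a functional assay (aorta) with Oryctolagus cuniculus as the target; on this read-out lower numbers stand for tighter binding and higher numbers for weaker binding:
Compound 1 `COc1cc(C(C)=O)ccc1OCCCN1CCC(C(c2ccc(F)cc2)c2ccc(F)cc2)CC1`: 1.59 nM
Compound 2 `Fc1ccc(OCCCN2CCC(C(c3ccc(F)cc3)c3ccc(F)cc3)CC2)cc1`: 1.26 nM

Compound 2 stands level with compound 1, within the scatter. For the measured compounds named here, the only measured step, a 1.3-fold lower number from compound 1 to compound 2 (0.10 log units; within the scatter), put 4-fluorophenyl in place of 4-acetyl-2-methoxyphenyl on the oxygen. Compound 3 `COc1ccc(OCCCN2CCC(C(c3ccc(F)cc3)c3ccc(F)cc3)CC2)cc1` departs from compound 2 by methoxy in place of fluoro on an aromatic carbon. That one step bears on this change only loosely, and it stayed within the scatter, so no step beyond the scatter is expected in this assay, in either direction. The expected step is a 1.3-fold higher number from compound 2 to compound 3 (0.10 log units; within the scatter). For compound 3 the estimated value is 1.6 nM, with an expected range of 0.6 nM to 4.5 nM.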

Compound 3, dissociation constant: 2.51 nM
The estimate for compound 3 lay 1.6-fold (0.20 log units) below the measured number; measured number inside the range.
By their numbers in this assay, from the lowest: compounds 2, 1 and 3 (each within the scatter of the next).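

In this assay, methoxy in place of fluoro on an aromatic carbon, para to a large group, gives a 2.0-fold higher number from compound 2 to compound 3 (0.30 log units; within the scatter), so this position tolerates either group within the scatter. The 4-methoxyphenyl in place of 4-acetyl-2-methoxyphenyl gives a 1.6-fold higher number from compound 1 to compound 3 (0.20 log units; within the scatter), which also leaves the two groups indistinguishable and extends the flat reading to all three compounds. No supporting data explain this flat reading. As far as these compounds go, whether an amine or a carboxylic acid at this place would produce a step beyond the scatter remains open.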